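Acyl variation in a tetradecylamide threonine series

The source may report more compounds than this note shows. Statements on the series, on what has been measured and on what is new or still open speak of the compounds shown alone.

Measured so far:
compound 1 `CCCCCCCCCCCCCCNC(=O)[C@@H](NC(=O)c1ccccc1)[C@@H](C)O`: 118000 nM
compound 2 `CCCCCCCCCCCCCCNC(=O)[C@@H](NC(=O)/C=C/c1ccccc1)[C@@H](C)O`: 64900 nM

In a functional assay on A-431 cells (Homo sapiens) for cytotoxicity, read by MTT assay, with a stated time of 48 h (a higher number here means a weaker inhibitor, a lower number a stronger inhibitor), compound 1 gives 118000 nM and compound 2 gives 64900 nM. Among the compounds with values here, the two values sit within the scatter of each other; the only measured step, a 1.8-fold lower number from compound 1 to compound 2 (0.26 log units; within the scatter), does not separate them. Compound 3 `C/C=C/C=C/C(=O)N[C@H](C(=O)NCCCCCCCCCCCCCC)[C@@H](C)O` differs from compound 2 by prop-1-en-1-yl in place of phenyl on a double-bonded chain carbon bound to a double-bonded chain carbon. Within the data shown here, only that one step bears on this change, and it was within the scatter, so no step beyond the scatter is expected in this assay here either, with a slight rise not excluded. Compound 3 is therefore estimated at 90000 nM (range 35000 nM to 250000 nM), an expected step of a 1.4-fold higher number from compound 2 to compound 3 (0.14 log units; within the scatter).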

Compound 3, half-maximal inhibitory concentration: > 200000 nM
Compound 3 ended at the assay's limit (the forecaster's own chance of this, stated with the estimate: 20%); middle value at least 2.2-fold (0.34 log units) from the limit.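

In this assay, the phenyl on the double-bonded chain carbon bound to a double-bonded chain carbon proves to matter: with prop-1-en-1-yl in its place, the series shows its first change beyond the scatter, an at least 3.0-fold higher number from compound 2 to compound 3 (0.48 log units; beyond the scatter). The other change, penta-1,3-dien-1-yl in place of phenyl on a carbonyl carbon, does not separate its pair: an at least 1.6-fold higher number from compound 1 to compound 3 (0.22 log units; that floor lies within the scatter). Compound 3 stands at a limit of the assay: the limit of > 200000 nM in this assay, at which 1 of the 3 values shown sits.

On these data alone, how far compound 3 lies past that limit remains open. Also open, as far as these compounds go, is whether an amine or a carboxylic acid on the phenyl of compound 2 would shift its number.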